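Benzyl for isopropyl on the acyl chain of compound 1

The compounds below may be only part of what the source reports. "The series", "measured", "known", "first", "only" and "open" are said of these compounds alone.

Measured compounds:
compound 1 `CC(C)CCC(=O)N[C@@H](C(=O)N1CCC(c2ccc(Cl)cc2)CC1)C(C)C` — 26 nM
compound 2 `CC[C@@H](C)[C@@H](NC(=O)c1ccccc1)C(=O)N1CCC(c2ccc(Cl)cc2)CC1` — 45 nM

Going by the values given here, in an assay on THP-1 cells for displacement of a labelled ligand from C-C chemokine receptor type 1 (Homo sapiens) (on this read-out lower numbers stand for stronger inhibition and higher numbers for weaker inhibition), compound 1 gives 26 nM, the lowest of the two numbers so far, although compound 2 at 45 nM lies within the usual scatter of it, so no order between the two can be read.

Compound 3 `CC(C)[C@@H](NC(=O)CCCc1ccccc1)C(=O)N1CCC(c2ccc(Cl)cc2)CC1` keeps the core of compound 1 and changes only the acyl chain. The difference is benzyl in place of isopropyl on a saturated chain carbon, two bonds along the chain from a carbonyl carbon. An aromatic ring on the acyl side is already present in compound 2, whose value in this assay sits close to that of compound 1, so a ring in that region seems tolerated.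

Among the compounds with values here, with no measured step of this kind, a change within the scatter, in either direction, is expected. Compound 3 is therefore expected to give about 22 nM, with a range from 8 nM to 65 nM. That estimate means an expected step of a 1.2-fold lower number from compound 1 to compound 3 (0.07 log units; within the scatter), which is expected to stay within the scatter.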

Compound 3, half-maximal inhibitory concentration: 95 nM
For compound 3 the middle estimate is 4.3-fold (0.64 log units) below the measured one; the whole stated range lies below it.
By their numbers in this assay, from the lowest: compounds 1 and 2 (each within the scatter of the next); then compound 3.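

In this assay, benzyl in place of isopropyl on a saturated chain carbon, two bonds along the chain from a carbonyl carbon, gives a 3.7-fold higher number from compound 1 to compound 3 (0.56 log units; beyond the scatter). Going by these compounds alone, this is the first single-place change, and it shows that this position of the acyl chain responds to the swap, if only modestly, with compound 3 still reading 95 nM. No measurement here bears on why the number rises.

Within the data shown here, the single step leaves open whether the rise goes with the aromatic ring or with the larger group as such, and a cyclohexylmethyl group at this position would separate the two. Also open, on these data alone, is how an amine or a carboxylic acid at the end of the chain would read.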